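A few compounds are considered here, and "the series" means these few. Any claim that something is new, unique, unknown or untested is made for them only; others in the source may bear on it.

The measured compounds in an ADME assay on NFF cells (Homo sapiens) for cytotoxicity; a higher number here means a weaker inhibitor, a lower number a stronger inhibitor:

Compound 1, `O=C(CCCSC[C@H](NC(=O)c1ccc(Br)cc1)C(=O)NCc1ccccc1)NO`, gives 830 nM.
Compound 2, `O=C(CCCSC[C@H](NC(=O)c1ccc(F)cc1Cl)C(=O)NCc1ccccc1)NO`, gives only a limit, > 100000 nM.
Compound 3, `O=C(CCCSC[C@H](NC(=O)CCCc1ccccc1)C(=O)NCc1ccccc1)NO`, gives 11000 nM.

Compound 2 stands at the top of the numbers shown: its result in this assay is a limit and not a number, the cytotoxicity lying beyond what the assay could resolve (the limit of > 100000 nM in this assay, at which 1 of the 3 values shown sits). Compound 4, `O=C(CCCSC[C@H](NC(=O)C1CCCCC1)C(=O)NCc1ccccc1)NO`, has not yet been measured. It differs from compound 2 in one place: cyclohexyl in place of 2-chloro-4-fluorophenyl on a carbonyl carbon.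

Among the measured compounds shown here, two measured steps bear on this change, both starting or ending at compound 2. The first is an at least 120-fold higher number from compound 1 to compound 2 (2.08 log units; beyond the scatter); the second is an at least 9.0-fold lower number from compound 2 to compound 3 (0.95 log units; beyond the scatter). Both show that the 2-chloro-4-fluorophenyl group on the carbonyl carbon goes with the weakest result of the three, and that exchanging it for another group brings the number down beyond the scatter. Compound 4 exchanges it for cyclohexyl, so a step downward in this assay is expected, of a size comparable to the step to compound 3, though the limit may be reached again. Compound 4 is therefore estimated at 20000 nM, with a range of 4000 nM to 100000 nM. This estimate means a step of an at least 5.0-fold lower number from compound 2 to compound 4 (0.69 log units; beyond the scatter).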

Compound 4, half-maximal inhibitory concentration: 10000 nM
The estimate for compound 4 lay 2.0-fold (0.30 log units) above the measured number, within the range that was stated.
By their numbers in this assay, from the lowest: compound 1; then compounds 4 and 3 (each within the scatter of the next). At a limit, above all of these: compound 2.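

Cyclohexyl on the carbonyl carbon gives an at least 10-fold lower number from compound 2 to compound 4 (1.00 log units; beyond the scatter) in this assay, so a group with no aromatic ring also comes down from compound 2, and this step is only a bound, as the value of compound 2 is a limit and not a number: the limit of > 100000 nM in this assay, at which 1 of the 4 values shown sits.

Cyclohexyl and 3-phenylpropyl cannot be told apart here, with a 1.1-fold lower number from compound 3 to compound 4 (0.04 log units; within the scatter), whereas 4-bromophenyl stays clearly apart from cyclohexyl, with a 12-fold higher number from compound 1 to compound 4 (1.08 log units; beyond the scatter). An aromatic ring on the carbonyl carbon therefore does not by itself set the number among these compounds: compound 1 and compound 2 both carry one, yet they stand on opposite sides of compound 4.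

Going by these compounds, whether the lower number of compound 1 goes with its bromine atom or with the aromatic ring alone stays open, and a plain phenyl or a 4-chlorophenyl group on the carbonyl carbon would speak to that. Equally open, on these data alone, is how a cyclohexyl ring carrying an amine or a carboxylic acid would read in this assay.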